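Aryl swap on the shared core: acid dissociation notes

A few compounds are considered here, and "the series" means these few. Any claim that something is new, unique, unknown or untested is made for them only; others in the source may bear on it.

Compound 1 `COc1ccc(F)cc1CNCCCNc1ccnc2cc(Cc3ccc(C#N)cc3)ccc12` gives 9.47 in a physicochemical assay for acid dissociation. Compound 3 `COc1cccc(CNCCCNc2ccnc3cc(Cc4cccc(C(F)(F)F)c4)ccc23)c1O` gives 9.47, the same number at the digits given, so compound 1 stands level with compound 3. Compound 2 `COc1cccc(Oc2ccc3c(NCCCNCc4cccc(OC)c4O)ccnc3c2)c1` gives 9.28; it is the furthest of the three from compound 1, and that gap is within the scatter. Among the measured compounds shown here, the only step measured between two compounds that differ in one place is a number 0.19 log units higher from compound 2 to compound 3 (within the scatter), a change of the group on the aromatic carbon of the shared core that left the number within the scatter.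

Compound 4 `COc1ccc(-c2ccc3c(NCCCNCc4cc(F)ccc4OC)ccnc3c2)cc1` is not yet measured. It differs from compound 1 at that same place: 4-methoxyphenyl in place of 4-cyanobenzyl on an aromatic carbon. For the measured compounds named here, the one step that bears on it, from compound 2 to compound 3, was within the scatter, and the proton measured is well removed from this carbon, so no step beyond the scatter is expected in the measurement from compound 1 to compound 4, a number 0.02 log units lower from compound 1 to compound 4 (within the scatter). Compound 4 is therefore estimated at 9.45, with a range from 9.15 to 9.75.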

Compound 4, acid dissociation constant: 9.47
Beside the measured number, compound 4's estimate is 0.02 log units below it; measured number inside the range.
By their numbers in this assay, from the lowest: compounds 2, 1, 3 and 4 (each within the scatter of the next).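

In this assay there is no change at the digits printed from compound 1 to compound 4 (within the scatter) with 4-methoxyphenyl in place of 4-cyanobenzyl on this aromatic carbon of the shared core. This change puts a phenyl group in place of a benzyl group and removes the nitrile, and it gives a second step at this position alongside a number 0.19 log units higher from compound 2 to compound 3 (within the scatter), so both steps read here lie within the scatter and none of the compounds shown goes against that. The data shown hold nothing that explains this result.

All four groups shown at this position carry an aromatic ring of carbon and no net charge. Going by these compounds, whether a carboxylic acid or a small aliphatic amine on the same aromatic carbon would also stay within the scatter in this assay remains open.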